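The compounds below may be only part of what the source reports. "The series", "measured", "known", "first", "only" and "open" are said of these compounds alone.

In an ADME assay on microsomes from liver (Rattus norvegicus) for metabolic stability (on this read-out lower numbers stand for a shorter-lived compound and higher numbers for a longer-lived compound), compound 1 (`Nc1nc(NCCNc2ncc(-c3ncc[nH]3)c(-c3ccc(F)cc3Cl)n2)ccc1[N+](=O)[O-]`) is reported only as a limit, > 0.5 h. Compound 2 (`Nc1nc(NCCNc2ncc(-c3ncc[nH]3)c(-c3cc(F)c(Cl)cc3Cl)n2)ccc1[N+](=O)[O-]`) is also reported only as a limit, > 0.5 h. Compound 2 therefore has no number of its own, and the whole evidence so far is the limit of > 0.5 h in this assay, at which 2 of the 2 values shown sit. Among the measured compounds shown here, the one measured step that bears on the next change is a step that the two limits leave unreadable from compound 1 to compound 2, with 2,4-dichloro-5-fluorophenyl in place of 2-chloro-4-fluorophenyl on an aromatic carbon. It offers no size to carry forward.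

Compound 3 (`Cc1cc(Cl)ccc1-c1nc(NCCNc2ccc([N+](=O)[O-])c(N)n2)ncc1-c1ncc[nH]1`) changes the group on that same aromatic carbon, ortho to a 1H-imidazol-2-yl group: 4-chloro-2-methylphenyl in place of 2,4-dichloro-5-fluorophenyl on an aromatic carbon. In words, 4-chloro-2-methylphenyl stands in place of 2,4-dichloro-5-fluorophenyl. With no readable step in this assay, no step beyond the usual scatter is expected, and no direction can be favoured. The expected outcome is a number no higher from compound 2 to compound 3 (the limit leaves the size open), which is an estimate only. Compound 3 is expected at 0.5 h, with an estimated range from 0.3 h to 1 h, and it may well be reported only as a limit again.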

Compound 3, half-life: > 0.5 h
Compound 3: only a limit was reported; the forecaster's own chance of this, stated with the estimate: 65%; the middle value lies on the limit itself.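

In this assay compound 3 is again reported only as a limit, > 0.5 h. Among the compounds shown here, the steps among compound 1, compound 2 and compound 3 therefore cannot be read, and no new step emerges. The evidence stands as follows: the limit of > 0.5 h in this assay, at which 3 of the 3 values shown sit. As far as these compounds go, the actual half-lives of these three compounds, and whether their substituted phenyl groups separate them at all, remain open.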